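Swapping One Small Ring for Another on the Sulfonyl Side

The source may hold more compounds than are shown below. What is called first, only, known or untested is meant among the compounds shown, and "the series" means these compounds.

Measured so far, in a functional assay, tested at 75 ug/mL; on this read-out lower numbers stand for a weaker effect and higher numbers for a stronger effect at the one concentration tested:
compound 1, `COc1ccc(C2=NN(c3ccccc3)C(c3ccc(C)cc3)C2S(=O)(=O)CC2=NCCO2)cc1`, gives 64.3%;
compound 2, `COc1ccc(C2=NN(c3ccccc3)C(c3ccc(C)cc3)C2S(=O)(=O)CC2=NCCS2)cc1`, gives 43.9%;
compound 3, `COc1ccc(C2=NOC(c3ccc(C)cc3)C2S(=O)(=O)CC2=NCCO2)cc1`, gives 66.6%.

Compound 1 and compound 2 share one core and differ in a single spot: a group of 5 heavy atoms (3 carbon, 1 nitrogen, 1 sulfur; one five-membered non-aromatic ring with 2 hetero atoms) in place of a group of 5 heavy atoms (3 carbon, 1 nitrogen, 1 oxygen; one five-membered non-aromatic ring with 2 hetero atoms), on a saturated chain carbon bound to a sulfonyl sulfur. This change brought a step of a number 20.4 percentage points lower from compound 1 to compound 2 (beyond the scatter).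

Compound 3 is built on a different core. How its core differs from that of compound 1 is not broken down here; what can be said is that the two values of compound 1 and compound 3 in this assay lie within the scatter of each other.

Compound 4, `COc1ccc(C2=NOC(c3ccc(C)cc3)C2S(=O)(=O)CC2=NCCS2)cc1`, has not been measured. It stands to compound 3 exactly as compound 2 stands to compound 1: a group of 5 heavy atoms (3 carbon, 1 nitrogen, 1 sulfur; one five-membered non-aromatic ring with 2 hetero atoms) in place of a group of 5 heavy atoms (3 carbon, 1 nitrogen, 1 oxygen; one five-membered non-aromatic ring with 2 hetero atoms), on a saturated chain carbon bound to a sulfonyl sulfur. Since the place around the change is described in the same words in both pairs, this is the same change, now made on the core of compound 3.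

If the change behaves as it did before, a step of about a number 20.6 percentage points lower from compound 3 to compound 4 (beyond the scatter) is expected from compound 3 to compound 4, resting on the single earlier step of a number 20.4 percentage points lower from compound 1 to compound 2 (beyond the scatter). Compound 4 is therefore estimated to give 46% in this assay, with a plausible range from 30% to 62%.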

Compound 4, a percentage reported as activity, at one concentration (the size of the read-out at that concentration, not a potency): 49.7%
Estimate against measurement, compound 4: 3.7 percentage points below, and the stated range covers the measured number.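

In this assay, putting the sulfur-bearing five-membered ring in place of the oxygen-bearing one on the core of compound 3 gave a step of a number 16.9 percentage points lower from compound 3 to compound 4 (beyond the scatter). Set beside the earlier step, the change lowers the number by a similar amount on both cores, so in this small set its effect carries over from one core to the other: the same change on two cores in this assay, a number 20.4 percentage points lower (beyond the scatter) from compound 1 to compound 2 and a number 16.9 percentage points lower (beyond the scatter) from compound 3 to compound 4, 3.5 percentage points apart, within the scatter of two such steps. For the compounds shown here, this rests on only two pairs of compounds, each read at one concentration, so it does not show that the change would behave the same way on any further core, nor does it explain why the sulfur-bearing ring gives the lower number.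

On these data alone, it remains open how a different group would compare on the saturated chain carbon bound to a sulfonyl sulfur, for example a five-membered ring with a second nitrogen in place of the oxygen or sulfur, or an open-chain amine. Also open, as far as these compounds go, is whether the same step would appear at other concentrations.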